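A few compounds are considered here, and "the series" means these few. Any claim that something is new, unique, unknown or untested is made for them only; others in the source may bear on it.

Measured compounds:
compound 1, `Cc1nc(N)c2nc(O)n(Cc3ccccc3)c2n1`: 3 mg/kg
compound 2, `COc1nc(N)c2nc(O)n(Cc3ccccc3)c2n1`: > 1 mg/kg

In a functional assay on the whole organism for activation, with Mus musculus as the target (a higher number here means that more compound is needed for the effect, a lower number that less compound is needed), compound 1 gives 3 mg/kg. For compound 2 the result is only a limit, > 1 mg/kg, so where compound 2 stands on the numbers is not fixed. That result reads as the limit of > 1 mg/kg in this assay, at which 1 of the 2 values shown sits. The step that the limit leaves unreadable from compound 1 to compound 2 cannot be sized. Compound 3, `CSc1nc(N)c2nc(O)n(Cc3ccccc3)c2n1`, has not yet been measured in this assay. It differs from compound 2 by methylsulfanyl in place of methoxy on an aromatic carbon. No measured step bears on this change: the only step shown, that from compound 1 to compound 2, is unreadable, and nothing here speaks to methylsulfanyl in place of methoxy. Among the measured compounds shown here, with no step to draw on, compound 3 is expected to sit at an estimated 3 mg/kg, with a range from 1 mg/kg to 10 mg/kg. The implied step is estimated at a step that the limit leaves unreadable from compound 2 to compound 3. A limit rather than a number remains a real possibility.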

Compound 3, minimum effective dose: 0.1 mg/kg
Compound 3: middle estimate off by 30-fold (1.48 log units), on the high side, and the stated range ends above it.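

In this assay, the aromatic carbon between two ring nitrogen atoms now proves sensitive to the group it carries. Methylsulfanyl in place of methoxy gives an at least 10-fold lower number from compound 2 to compound 3 (1.00 log units; beyond the scatter), and methylsulfanyl in place of methyl gives a 30-fold lower number from compound 1 to compound 3 (1.48 log units; beyond the scatter). The earlier pair showed none of this, and the step between compound 1 and compound 2 still cannot be read, while the first step above gives only a minimum size, set by a limit: the limit of > 1 mg/kg in this assay, at which 1 of the 3 values shown sits.

The compounds shown leave open whether a longer chain on the sulfur, such as ethylsulfanyl, or an amine on this same carbon would keep the low dose seen for compound 3. They also leave open where compound 2 stands relative to compound 1.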